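This account rests on a few compounds, and the source may have more. Where it says the series, first, only, none or still open, it means among the compounds named here.

Measured so far:
Compound 1 `CCN(Cc1cncs1)C(=O)COc1ccc(C)cc1` gives 1100 nM in an assay on HEK293 cells for agonist activity at transient receptor potential cation channel subfamily M member 8 (Homo sapiens), read by fluorescence and calcium flux, with a stated time of 15 min; a higher number here means that more compound is needed for the effect, a lower number that less compound is needed.
Compound 2 `CCN(Cc1ccsc1)C(=O)COc1ccc(C)cc1` gives 88 nM in this assay.

Among the compounds with values here, compound 2 stands lowest of the two numbers; its only neighbour is compound 1, and the step of a 13-fold lower number from compound 1 to compound 2 (1.10 log units; beyond the scatter) was large. Compound 3 `CCN(Cc1ccc(C)s1)C(=O)COc1ccc(C)cc1` differs from compound 2 by 5-methylthiophen-2-yl in place of thiophen-3-yl on a saturated chain carbon bound to an amide-type nitrogen. Within the data shown here, the one measured step exchanged a different five-membered aromatic ring entirely, so it offers little guidance for keeping the same ring while shifting its attachment and adding a methyl group. For compound 3 the expectation is a small step, a 1.3-fold higher number from compound 2 to compound 3 (0.10 log units; within the scatter), likely within the scatter, giving an estimated 110 nM with a range from 35 nM to 350 nM.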

Compound 3, half-maximal effective concentration: 178 nM
Compound 3: the middle estimate sits 1.6-fold (0.21 log units) below what was measured; the measured number falls inside the stated range.
By their numbers in this assay, from the lowest: compound 2; then compound 3; then compound 1.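

With 5-methylthiophen-2-yl in place of thiophen-3-yl, this assay shows a 2.0-fold higher number from compound 2 to compound 3 (0.31 log units; beyond the scatter), so this place on the saturated chain carbon tolerates a change of thiophene form with only a modest loss. The gain over the 1,3-thiazol-5-yl group largely survives, with a 6.2-fold lower number from compound 1 to compound 3 (0.79 log units; beyond the scatter). No available evidence explains either step.

From the compounds shown here alone, the ring attachment and the methyl group change together here, so their separate contributions remain open. Also open, going by these compounds, is how a 5-chlorothiophen-2-yl group or a phenyl ring would compare at this place.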